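The compounds below may be only part of what the source reports. "The series", "measured", "known", "first", "only" and "open" are said of these compounds alone.

Working notes on the series.

Compound 1 `C=C1C[C@]23C[C@@]1(O)CC[C@H]2c1ccc(OS(=O)(=O)c2ccc(C)cc2)c(C)c1[C@@H]3Cn1cc(-c2ccc(Cl)cc2)nn1` carries a tosylate on the aromatic ring of the core, a methylene without a neighbouring carbonyl, and a triazole bearing a 4-chlorophenyl group. In a functional assay on SW480 cells (Homo sapiens) for cytotoxicity, read by MTT assay, with a stated time of 4 days (a lower number here means a stronger inhibitor, a higher number a weaker inhibitor), compound 1 gives only a limit, > 20000 nM, and no number. Within the data shown here, the other measured members differ from compound 1 in more than one place, so no single step to them is drawn. Compound 2 `C=C1C(=O)[C@]23C[C@@]1(O)CC[C@H]2c1ccc(OS(=O)(=O)c2ccc(C)cc2)c(C)c1[C@@H]3Cn1cc(-c2ccc(Cl)cc2)nn1` adds a carbonyl next to the exocyclic methylene and in this assay gives 2390 nM. Compound 3 `C=C1C(=O)[C@]23C[C@@]1(O)CC[C@H]2c1ccc(O)c(C)c1[C@@H]3Cn1cc(-c2ccccc2)nn1` keeps that carbonyl, has a free phenol in place of the tosylate and an unsubstituted phenyl on the triazole, and in this assay gives 260 nM. Of the three values shown, compound 1 is the one at the limit of > 20000 nM in this assay, at which 1 of the 3 values shown sits, the weakest end of what is seen.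

The step to compound 4 `C=C1C[C@]23C[C@@]1(O)CC[C@H]2c1ccc(OS(=O)(=O)c2ccc(C)cc2)c(C)c1[C@@H]3Cn1cc(-c2ccc(C)cc2)nn1` is methyl in place of chloro on an aromatic carbon, with nothing else touched. The core, the tosylate and the methylene without carbonyl of compound 1 are all retained. Among the measured compounds shown here, no measured pair shows this exchange, so the step is expected to be small, with no direction beyond the scatter, and compound 4 is expected to sit where compound 1 sits. The estimated step that the limit leaves unreadable from compound 1 to compound 4 is expected to be within the scatter. For compound 4 the estimate in this assay is 25000 nM, in the range 8000 nM to 80000 nM, most likely again reported only as a limit.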

Compound 4, half-maximal inhibitory concentration: > 20000 nM
Compound 4 was reported as a limit; the forecaster's own chance of this, stated with the estimate: 70%; the middle value does not contradict the limit.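

Compound 4 is reported only as a limit, as is compound 1: the limit of > 20000 nM in this assay, at which 2 of the 4 values shown sit.

Among these compounds, no step between compound 1 and compound 4 can be read from these two limits. The compounds shown leave open whether 4-chlorophenyl to 4-methylphenyl changes the value where the shared core gives a measurable number in this assay.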